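Swapping 2,2,2-trifluoroethoxy for trifluoromethyl on a carbonyl carbon

A few compounds are considered here, and "the series" means these few. Any claim that something is new, unique, unknown or untested is made for them only; others in the source may bear on it.

- Compound 1 `CCOC(=O)NCCCOc1cc2c(-n3nc(-c4ccccn4)nc3N)ncnc2cc1OC`: 16000 nM
- Compound 2 `COc1cc2ncnc(-n3nc(-c4ccccn4)nc3N)c2cc1OCCCNC(=O)OC(C)C`: 18000 nM
- Compound 3 `COc1cc2ncnc(-n3nc(-c4ccccn4)nc3N)c2cc1OCCCNC(=O)OCC(F)(F)F`: 100 nM

All three values come from a physicochemical assay for solubility, in phosphate buffer, with a stated time of 18 h, at pH 7.4 (a lower number here means a less soluble compound, a higher number a more soluble compound), and compound 3 has the lowest number of the three. Compound 4 `COc1cc2ncnc(-n3nc(-c4ccccn4)nc3N)c2cc1OCCCNC(=O)C(F)(F)F` differs from compound 3 by one change: trifluoromethyl in place of 2,2,2-trifluoroethoxy on a carbonyl carbon. Among the compounds with values here, no measured step makes this exact swap. The nearest evidence is two large drops, a 160-fold lower number from compound 1 to compound 3 (2.20 log units; beyond the scatter) and a 180-fold lower number from compound 2 to compound 3 (2.26 log units; beyond the scatter), while a 1.1-fold higher number from compound 1 to compound 2 (0.05 log units; within the scatter) stayed within the scatter. Compound 4 keeps the three fluorines but loses the 2,2,2-trifluoroethoxy group, so a partial rise is expected, with wide uncertainty. The expected change is a 10-fold higher number from compound 3 to compound 4 (1.00 log units; beyond the scatter). The estimate for compound 4 is 1000 nM, with an expected range from 120 nM to 10000 nM.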

Compound 4, solubility: 1000 nM
For compound 4 middle estimate and measured number coincide at the digits printed; low and high end bracket the measured number.
By their numbers in this assay, from the lowest: compound 3; then compound 4; then compounds 1 and 2 (each within the scatter of the next).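

Within this assay, trifluoromethyl in place of 2,2,2-trifluoroethoxy on the carbonyl carbon gives a clear rise (a 10-fold higher number from compound 3 to compound 4 (1.00 log units; beyond the scatter)), so keeping three fluorines at this position does not by itself hold the number at its lowest. Trifluoromethyl still reads well under isopropoxy (an 18-fold lower number from compound 2 to compound 4 (1.26 log units; beyond the scatter)) and ethoxy (a 16-fold lower number from compound 1 to compound 4 (1.20 log units; beyond the scatter)), so the swap recovers only part of the gap. Nothing measured here explains these differences. On these data alone, whether a plain methyl or an amine on the carbonyl carbon would read nearer compound 4 or nearer compound 1 remains open.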